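Replacing 4-methoxyphenyl with 2,4-dimethylphenyl in compound 4

A few compounds are considered here, and "the series" means these few. Any claim that something is new, unique, unknown or untested is made for them only; others in the source may bear on it.

Values in a functional assay on B16-F10 cells (Mus musculus) for antiproliferative activity, read by MTT assay, with a stated time of 48 h; on this read-out lower numbers stand for stronger inhibition and higher numbers for weaker inhibition
compound 1 `O=C(/C=C/c1ccc(O)c(O)c1)N1CCN(c2ccccc2Cl)CC1` gives 1.82 ug/mL
compound 2 `COc1ccccc1N1CCN(C(=O)/C=C/c2ccc(O)c(O)c2)CC1` gives 1.23 ug/mL
compound 3 `COc1ccc(N2CCN(C(=O)/C=C/c3ccc(O)c(O)c3)CC2)cc1` gives 1.21 ug/mL

At 1.21 ug/mL, compound 3 stands within the usual scatter of both other compounds. Compound 4 `Cc1ccc(N2CCN(C(=O)/C=C/c3ccc(O)c(O)c3)CC2)c(C)c1` has not yet been measured. It carries 2,4-dimethylphenyl in place of 4-methoxyphenyl on an amine nitrogen in a ring. For the measured compounds named here, three measured steps bear on this change: a 1.5-fold lower number from compound 1 to compound 2 (0.17 log units; within the scatter), a 1.5-fold lower number from compound 1 to compound 3 (0.18 log units; within the scatter) and a 1.0-fold lower number from compound 2 to compound 3 (0.01 log units; within the scatter). Going by the values given here, all three stay within the scatter, although no measured compound carries 2,4-dimethylphenyl. No change beyond the scatter is therefore expected in this assay. The expected step is a 1.2-fold higher number from compound 3 to compound 4 (0.06 log units; within the scatter). The estimate for compound 4 is 1.4 ug/mL, with an expected range from 0.7 ug/mL to 2.8 ug/mL.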

Compound 4, half-maximal inhibitory concentration: 1.43 ug/mL
The estimate for compound 4 lay 1.0-fold (0.01 log units) below the measured number; low and high end bracket the measured number.
By their numbers in this assay, from the lowest: compounds 3, 2, 4 and 1 (each within the scatter of the next).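

In this assay the steps are a 1.2-fold higher number from compound 3 to compound 4 (0.07 log units; within the scatter) and a 1.2-fold higher number from compound 2 to compound 4 (0.07 log units; within the scatter) and also a 1.3-fold lower number from compound 1 to compound 4 (0.10 log units; within the scatter) so 2,4-dimethylphenyl on the amine nitrogen in the ring leaves the number within the scatter of all three earlier compounds. This extends the earlier picture to an aryl group with two methyl substituents, and the change from 4-methoxyphenyl also removes the hydrogen-bond acceptor of that group without a step beyond the scatter. On these data alone, whether an amine or a carboxylic acid on this phenyl ring would shift the number beyond the scatter stays open. No measurement shown here accounts for how close these numbers lie.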